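The compounds below may be only part of what the source reports. "The series", "measured", "known", "first", "only" and "open" are said of these compounds alone.

Three compounds have numbers in an ADME assay on the whole organism (Rattus norvegicus) for pharmacokinetics, at a dose of 1 mg/kg by the intravenous route; on this read-out lower numbers stand for slow clearance and higher numbers for fast clearance. Compound 1 `O=C(c1cnco1)N1CCC(C(=O)N2N=CC[C@H]2c2ccccc2)CC1` gives 42 mL/min/kg, compound 2 `N#Cc1cnc(N2CCC(C(=O)N3N=CC[C@H]3c3cc(F)cc(F)c3)CC2)cn1` gives 47 mL/min/kg and compound 3 `O=C(c1cn[nH]c1)N1CCC(C(=O)N2N=CCC2c2ccccc2)CC1` gives 46 mL/min/kg. Compound 1 therefore stands level with the other two, since all three numbers lie within the scatter of one another, although the structures of compound 2 and compound 3 differ from that of compound 1.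

The unmeasured compound 4 `CC(=O)N1CCC(C(=O)N2N=CC[C@H]2c2ccccc2)CC1` keeps the core of compound 1 and alters one group: methyl in place of 1,3-oxazol-5-yl on a carbonyl carbon. Seen one bond further out, (1,3-oxazol-5-yl)carbonyl becomes acetyl. Going by the values given here, no measured pair shows this change on its own, and the only guide in this assay is the narrow spread of the three known numbers, with compound 1 at 42 mL/min/kg as the starting point. No shift beyond the scatter is expected, and the estimated step is a 1.1-fold lower number from compound 1 to compound 4 (0.02 log units; within the scatter). For compound 4 the expected clearance is 40 mL/min/kg, with an estimated range of 22 mL/min/kg to 65 mL/min/kg.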

Compound 4, clearance: 44 mL/min/kg
Compound 4: middle estimate off by 1.1-fold (0.04 log units), on the low side; the range from low to high includes it.
By their numbers in this assay, from the lowest: compounds 1, 4, 3 and 2 (each within the scatter of the next).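

In this assay, putting methyl in place of 1,3-oxazol-5-yl on a carbonyl carbon gives a 1.0-fold higher number from compound 1 to compound 4 (0.02 log units; within the scatter), the only single-place comparison among the compounds shown. At this position, therefore, a five-membered aromatic ring with 5 heavy atoms and 2 hydrogen-bond acceptors gives way to a single carbon with no ring and no acceptors, and the number stays within the scatter. No measurement at hand bears on the reason for this result.

On these data alone, whether a group of another kind on this carbonyl carbon, such as an amine or a carboxylic acid, would also leave the number in this assay within the scatter remains open. The compounds shown also leave open whether a single change elsewhere on the core of compound 1 would move it beyond the scatter.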